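The source may report more compounds than this note shows. Statements on the series, on what has been measured and on what is new or still open speak of the compounds shown alone.

Working notes on the series. The shared core carries an anilide on one side and an acyl group on the ring nitrogen on the other. Compound 1 `CCCC(=O)N1c2ccccc2CCC1C(=O)Nc1ccccc1C(F)(F)F` bears a propyl carbonyl on that nitrogen and a trifluoromethyl on the anilide ring. In a functional assay on MDA-MB-231 cells (Homo sapiens) for cytotoxicity, read by sulforhodamine B assay, with a stated time of 72 h (a lower number here means a stronger inhibitor of growth, a higher number a weaker inhibitor of growth), compound 1 gives only a limit, > 70000 nM, so its place on the scale is known only as that limit (the limit of > 70000 nM in this assay, at which 1 of the 2 values shown sits). Compound 2 `CCCCCCCCC(=O)N1c2ccccc2CCC1C(=O)Nc1cc(C(F)(F)F)cc(C(F)(F)F)c1` differs from compound 1 in two places at once, a longer chain on the carbonyl and a second trifluoromethyl on the anilide ring, and in this assay compound 2 gives 7530 nM. Going by the values given here, no single-point step between measured compounds exists, so no measured step size is at hand.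

Compound 3 `O=C(Nc1ccccc1C(F)(F)F)C1CCc2ccccc2N1C(=O)c1ccc(Cl)cc1` is the next compound for this assay. It differs from compound 1 by 4-chlorophenyl in place of propyl on a carbonyl carbon. The anilide half is unchanged from compound 1. Given that compound 1 sits at a limit, the expected step of an at least 2.3-fold lower number from compound 1 to compound 3 (0.36 log units; beyond the scatter) would carry compound 3 below that limit, although this is an estimate and a limit result remains possible. For compound 3 the expected value in this assay is 30000 nM, with a range from 8000 nM to 100000 nM.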

Compound 3, concentration for 50% growth inhibition: 533 nM
Estimate against measurement, compound 3: 56-fold (1.75 log units) above; measured number outside the range, below it.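

In this assay, going by these compounds alone, 4-chlorophenyl in place of propyl on a carbonyl carbon gives an at least 130-fold lower number from compound 1 to compound 3 (2.11 log units; beyond the scatter), the first single-point step. With the anilide half unchanged, the change at this carbonyl alone moves the result well beyond the scatter, which compound 2, changed in two places at once, could not show. Compound 1 stands at a limit, not at a number, so this step sets only a lower bound on the size of the change: the limit of > 70000 nM in this assay, at which 1 of the 3 values shown sits.

On these data alone, it remains open whether the step belongs to the aromatic ring or to the chlorine, a question that plain phenyl or cyclohexyl on the same carbonyl carbon would bear on. Also open, as far as these compounds go, is whether a longer alkyl chain in place of propyl, with the anilide half held as in compound 1, or 4-chlorophenyl on the carbonyl combined with the anilide ring of compound 2, would give a similar result.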